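The source may hold more compounds than are shown below. What is called first, only, known or untested is meant among the compounds shown, and "the series" means these compounds.

Measured so far:
- compound 1 `O=[N+]([O-])c1cn2c(n1)OCC(COc1ccc(-c3ccc(OC(F)(F)F)cc3)nc1)C2` gives > 10 ug/mL (a limit)
- compound 2 `CN1CC(OCc2ccc(OCc3ccccc3)cc2)Cn2nc([N+](=O)[O-])cc21` gives > 10 ug/mL (a limit)
- compound 3 `O=[N+]([O-])c1cn2c(n1)[S+]([O-])CC(OCc1ccc(OCc3ccccc3)cc1)C2` gives > 10 ug/mL (a limit)

In an ADME assay on L929 cells (Mus musculus) for cytotoxicity (a higher number here means a weaker inhibitor, a lower number a stronger inhibitor), compound 1 gives > 10 ug/mL as a limit and not as a number. For the measured compounds named here, the series so far is summed up by the limit of > 10 ug/mL in this assay, at which 3 of the 3 values shown sit, and no number has been reported. Compound 4 `O=[N+]([O-])c1cn2c(n1)OCC(COc1ccc(-c3ccc(C(F)(F)F)cc3)nc1)C2` has trifluoromethyl in place of trifluoromethoxy on an aromatic carbon, with trifluoromethyl in place of trifluoromethoxy on an aromatic carbon as the counted difference from compound 1. Going by the values given here, no measured step in this assay gives a scale for this change, so no step beyond the scatter is expected. The estimated step that the limit leaves unreadable from compound 1 to compound 4 is expected to stay within the scatter. This expectation rests on compound 1, whose > 10 ug/mL is a limit. Compound 4 is estimated at 15 ug/mL with an expected range from 8 ug/mL to 50 ug/mL in this measurement.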

Compound 4, half-maximal inhibitory concentration: > 10 ug/mL
Compound 4 ended at the assay's limit; the forecaster's own chance of this, stated with the estimate: 85%; the middle value is on the limit's open side.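

No step can be read from compound 1 to compound 4 in this assay, as both values are limits: the limit of > 10 ug/mL in this assay, at which 4 of the 4 values shown sit.

The compounds shown leave open how trifluoromethyl and trifluoromethoxy compare in this assay, and where any compound's actual value lies.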